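Extending the alkylsulfanyl chain from compound 3 to compound 4

The source may hold more compounds than are shown below. What is called first, only, known or untested is meant among the compounds shown, and "the series" means these compounds.

Compound 1 `CCCCOc1nccnc1C1CN2CCC1CC2`: 15%
Compound 2 `CCCCCOc1nccnc1C1CN2CCC1CC2`: 32%
Compound 3 `CCCCSc1nccnc1C1CN2CCC1CC2`: 5%

In a functional assay on A9L-m1 cells with A9 (Mus musculus) as the target (on this read-out higher numbers stand for larger maximal responses and lower numbers for smaller maximal responses), compound 3 lies a number 10 percentage points lower from compound 1 to compound 3 (within the scatter) and a number 27 percentage points lower from compound 2 to compound 3 (beyond the scatter). Compound 4 `CCCCCCSc1nccnc1C1CN2CCC1CC2` differs from compound 3 by ethyl in place of hydrogen on a saturated chain carbon, four bonds along the chain from a sulfur. Going by the values given here, the one measured step that bears on this is the chain extension on the oxygen analogue, a number 17 percentage points higher from compound 1 to compound 2 (beyond the scatter), which points upward; the extension here is by ethyl rather than methyl and sits on a sulfur, so the transfer is uncertain. Compound 4 is therefore expected to show a modest rise in this assay, estimated as a number 17 percentage points higher from compound 3 to compound 4 (beyond the scatter). The expected value for compound 4 is 22%, within a range of 5% to 45%.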

Compound 4, largest response reached (reported as maximum), in percent of the reference or control that the assay uses: 16%
Beside the measured number, compound 4's estimate is 6 percentage points above it; the measured number falls inside the stated range.
By their numbers in this assay, from the lowest: compounds 3, 1 and 4 (each within the scatter of the next, the first and the last beyond it); then compound 2.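

In this assay lengthening the chain on sulfur also gives a higher number (a number 11 percentage points higher from compound 3 to compound 4 (beyond the scatter)), so the rise seen on the oxygen pair now has a counterpart in the sulfur pair. Hexylsulfanyl still falls short of pentyloxy (a number 16 percentage points lower from compound 2 to compound 4 (beyond the scatter)), while it cannot be told apart from butoxy (a number 1 percentage points higher from compound 1 to compound 4 (within the scatter)). Nothing available here accounts for these differences.

From the compounds shown here alone, whether the rise continues with a longer chain such as octylsulfanyl remains open. So does how hexyloxy would compare with hexylsulfanyl at the same chain length.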